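The source may hold more compounds than are shown below. What is called first, only, known or untested is meant among the compounds shown, and "the series" means these compounds.

Working notes on the series. Going by the values given here, in an in vitro assay on 293-EBNA cells for binding affinity to corticotropin-releasing factor receptor 1 (Homo sapiens) (on this read-out lower numbers stand for stronger inhibition and higher numbers for weaker inhibition), compound 1 `Cc1nc(N2CCCCC2)c2nnn(-c3ccc(C(C)C)cc3Br)c2n1` gives 46 nM, the higher of the two numbers measured so far; compound 2 `CCCC(CCC)Nc1nc(C)nc2c1nnn2-c1c(C)cc(C)cc1C` gives 4 nM, a gap beyond the scatter, but the two structures differ in more than one place. Compound 3 `COCC(COC)N(C)c1nc(C)nc2c1nnn2-c1ccc(C(C)C)cc1Br` is compound 1 with a single change: a group of 9 heavy atoms (6 carbon, 1 nitrogen, 2 oxygen; no ring) in place of a group of 6 heavy atoms (5 carbon, 1 nitrogen; one six-membered non-aromatic ring with 1 hetero atom), on an aromatic carbon. Among the compounds with values here, no pair of measured compounds isolates this change; compound 2 carries a group with no ring and gives the lower number, which is only a loose pointer. A moderate step toward a lower number is expected, a 3.1-fold lower number from compound 1 to compound 3 (0.49 log units; beyond the scatter). Compound 3 is estimated at 15 nM, with a range from 4 nM to 60 nM.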

Compound 3, inhibition constant: 21.3 nM
Estimate against measurement, compound 3: 1.4-fold (0.15 log units) below; low and high end bracket the measured number.
By their numbers in this assay, from the lowest: compound 2; then compound 3; then compound 1.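

In this assay, going by these compounds alone, replacing piperidin-1-yl with the ring-free group on an aromatic carbon next to the ring nitrogen gives a 2.2-fold lower number from compound 1 to compound 3 (0.33 log units; beyond the scatter), the first step to isolate a change at this position. This position therefore does not need the six-membered non-aromatic ring for the lower number, at least on the core of compound 1. No measurement at hand links the step to any property of either group.

A morpholine ring or a plain dimethylamino group here could separate loss of the ring from the arrival of the two oxygen atoms. Compound 2 differs from compound 3 in more than one place, so it cannot settle that question.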